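A few compounds are considered here, and "the series" means these few. Any claim that something is new, unique, unknown or untested is made for them only; others in the source may bear on it.

Working notes on the series. In a functional assay on A549 cells (Homo sapiens) for inhibition, read by MTT assay, with a stated time of 48 h, tested at 10 uM (on this read-out lower numbers stand for less inhibition of growth and higher numbers for more inhibition of growth at the one concentration tested), compound 1 `O=C(/C=C/c1ccc(OCc2cn(Cc3ccccc3Br)nn2)cc1)c1ccc(Br)cc1` gives 44%. Compound 2 `O=C(/C=C/c1ccc(OCc2cn(Cc3ccccc3)nn2)cc1)c1ccc([N+](=O)[O-])cc1` is reported in this assay only as "not active" (no number reported), so no single number places it among the values shown. Compound 3 `O=C(/C=C/c1ccc(OCc2cn(Cc3ccccc3Br)nn2)cc1)c1ccc([N+](=O)[O-])cc1` has not been run in this assay; it differs from compound 2 by bromo in place of hydrogen on an aromatic carbon. For the measured compounds named here, no measured pair isolates this change, and compound 1 differs from compound 3 at the ketone aryl as well, so the size of the step is open; a gain of modest size is expected rather than none. For compound 3 in this assay the estimate is 25%, within 5% to 50%.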

Compound 3, percent growth inhibition at one concentration: 42%
Beside the measured number, compound 3's estimate is 17 percentage points below it, within the range that was stated.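

In this assay compound 2, with benzyl, is reported as "not active" (no number reported), whereas compound 3, with 2-bromobenzyl, gives 42%; the size of this step cannot be read, but the nitro compound does carry a number once bromo is on this ring. With 2-bromobenzyl held, nitro in place of bromo on the ketone aryl gives a number 2 percentage points lower from compound 1 to compound 3 (within the scatter), so this assay does not separate these two groups. Still open, as far as these compounds go, is whether chloro or methoxy at the same place on the benzyl ring would read like bromo, and whether an amine on the ketone aryl would fit with 2-bromobenzyl. No measurement at hand speaks to the reason for these readings.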